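Shortening the Ether Side Chain to a Linear Alkyne

The source may hold more compounds than are shown below. What is called first, only, known or untested is meant among the compounds shown, and "the series" means these compounds.

Compound 1, `Nc1ccc2cccc(OCC3CCCC3)c2n1` — in an assay on cells with melanin-concentrating hormone receptor 1 (Homo sapiens) as the target, read by radioligand binding (on this read-out higher numbers stand for weaker inhibition and lower numbers for stronger inhibition), compound 1 gives 53 nM.
Compound 2, `Nc1ccc2cccc(OCCC(F)(F)F)c2n1` — in this assay compound 2 gives 722 nM.
Compound 3, `CC(C)Oc1cccc2ccc(N)nc12` — in this assay compound 3 gives 437 nM.

Compound 1 holds the lowest number of the three measured in this assay, and both steps that lead away from it run upward and beyond the scatter: an 8.2-fold higher number from compound 1 to compound 3 (0.92 log units; beyond the scatter) and a 14-fold higher number from compound 1 to compound 2 (1.13 log units; beyond the scatter). The step from compound 2 to compound 3 stays within the scatter, a 1.7-fold lower number from compound 2 to compound 3 (0.22 log units; within the scatter).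

Compound 4, `CCC#CCOc1cccc2ccc(N)nc12`, differs from compound 1 by but-1-yn-1-yl in place of cyclopentyl on a saturated chain carbon bound to an oxygen on an aromatic ring. Both measured steps from compound 1 bear on this move, as each exchanges the ring-bearing chain on the oxygen for a smaller open chain, and each raises the number, one large and one modest. A similar move toward weaker inhibition is therefore expected for compound 4 in this assay, because an 8.2-fold higher number from compound 1 to compound 3 (0.92 log units; beyond the scatter) and a 14-fold higher number from compound 1 to compound 2 (1.13 log units; beyond the scatter) both point that way, with the size likely between those two. Compound 4 is estimated at 250 nM, with a range of 80 nM to 800 nM, expected to read as a 4.7-fold higher number from compound 1 to compound 4 (0.67 log units; beyond the scatter).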

Compound 4, half-maximal inhibitory concentration: > 2000 nM
Compound 4 ended at the assay's limit; the forecaster's own chance of this, stated with the estimate: 2%; middle value at least 8.0-fold (0.90 log units) from the limit.
By their numbers in this assay, from the lowest: compound 1; then compounds 3 and 2 (each within the scatter of the next). At a limit, above all of these: compound 4.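

In this assay compound 4 reads at a limit of the assay, not at a number: the limit of > 2000 nM in this assay, at which 1 of the 4 values shown sits.

Pent-2-yn-1-yl on the oxygen gives an at least 37-fold higher number from compound 1 to compound 4 (1.57 log units; beyond the scatter), and it also stands clear of both smaller open chains, with an at least 4.5-fold higher number from compound 3 to compound 4 (0.66 log units; beyond the scatter) and an at least 2.7-fold higher number from compound 2 to compound 4 (0.44 log units; beyond the scatter). Open chains at this position are thus not interchangeable: the isopropyl and 3,3,3-trifluoropropyl compounds lie within the scatter of each other, whereas the chain with the triple bond separates from both.

Going by these compounds, whether the triple bond or the length of the chain carries this result stays open, as does the reading of a saturated pentyl chain on the same oxygen. Also open, on these data alone, is whether a cyclohexylmethyl group, or an amine at the end of a chain, would keep the number of compound 1.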